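A few compounds are considered here, and "the series" means these few. Any claim that something is new, unique, unknown or untested is made for them only; others in the source may bear on it.

Measured so far in an ADME assay on HeLa cells (Homo sapiens) for cytotoxicity, read by sulforhodamine B assay, with a stated time of 48 h, tested at 10 uM; on this read-out higher numbers stand for more inhibition at the one concentration tested (going by the name of the read-out) and lower numbers for less inhibition:
compound 1 `COc1nc2ccc(Br)cc2cc1C(c1ccccc1)n1cc(C2CC2)nn1` gives -5.84%
compound 2 `COc1nc2ccc(Br)cc2cc1C(c1ccccc1)n1cc(-c2ccccc2F)nn1` gives 14.1%

Compound 2 stands highest of the two numbers in this assay, compound 1 lying below it by a number 19.9 percentage points higher from compound 1 to compound 2 (beyond the scatter). Compound 3 `CCCCCCCCc1cn(C(c2ccccc2)c2cc3cc(Br)ccc3nc2OC)nn1` awaits measurement. Its change from compound 2: octyl in place of 2-fluorophenyl on an aromatic carbon. Within the data shown here, no measured step exchanges a ring for a chain at this carbon, so only a number 19.9 percentage points higher from compound 1 to compound 2 (beyond the scatter) bears on it, and loosely: it shows this carbon can shift the read-out modestly. A small rise or nothing beyond the scatter is expected; the expected step is a number 5.9 percentage points higher from compound 2 to compound 3 (within the scatter). Compound 3 is estimated at 20%, within -5% to 45%.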

Compound 3, a percentage reported as inhibition, at one concentration (the size of the read-out at that concentration, not a potency): 0.1%
Compound 3: middle estimate off by 19.9 percentage points, on the high side; measured number inside the range.
By their numbers in this assay, from the lowest: compounds 1 and 3 (each within the scatter of the next); then compound 2.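

In this assay, octyl in place of 2-fluorophenyl gives a number 14 percentage points lower from compound 2 to compound 3 (beyond the scatter), so a long chain at this aromatic carbon does not keep the higher number of compound 2. Octyl in place of cyclopropyl gives a number 5.9 percentage points higher from compound 1 to compound 3 (within the scatter), which leaves the chain and the small ring indistinguishable here, with only 2-fluorophenyl standing apart among the three groups. Nothing at hand explains this difference.

Open, as far as these compounds go, is whether the step belongs to the aromatic ring or to its fluorine, which plain phenyl would separate. Also open, from the compounds shown here alone, is whether a shorter chain, or a chain ending in an amine, would move the number at this carbon.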